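Dropping a Chloro Group from a Highly Permeable Compound

A few compounds are considered here, and "the series" means these few. Any claim that something is new, unique, unknown or untested is made for them only; others in the source may bear on it.

Compound 1 `COc1cccc(CNCCCNc2ccnc3cc(Oc4ccc(Cl)cc4)ccc23)c1O` holds the higher of the two numbers measured in an ADME assay for permeability, using PAMPA, with a stated time of 30 min, at pH 7.4; a lower number here means that the compound crosses the layer more slowly, a higher number that the compound crosses the layer faster: compound 1 gives 317 10^-6 cm/s, whereas compound 2 `Fc1ccc(Cc2ccc3c(NCCCNCc4ccco4)ccnc3c2)c(Cl)c1` in this assay gives 23 10^-6 cm/s, a gap beyond the scatter. Compound 3 `COc1cccc(CNCCCNc2ccnc3cc(Oc4ccccc4)ccc23)c1O` differs from compound 1 only by hydrogen in place of chloro on an aromatic carbon. Going by the values given here, no measured pair shows this change directly, so the expectation rests on compound 1 alone. The step of a 1.3-fold lower number from compound 1 to compound 3 (0.10 log units; within the scatter) is expected to be small, a slight drop that may not exceed the scatter. Compound 3 is therefore estimated at 250 10^-6 cm/s, within a range from 120 10^-6 cm/s to 500 10^-6 cm/s.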

Compound 3, apparent permeability: 317 10^-6 cm/s
Compound 3: the middle estimate sits 1.3-fold (0.10 log units) below what was measured; the measured number falls inside the stated range.
By their numbers in this assay, from the lowest: compound 2; then compounds 1 and 3 (each within the scatter of the next).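

In this assay, going by these compounds alone, the first direct pair for this change puts hydrogen in place of chloro on an aromatic carbon para to a large group, and it reads no change at the digits printed from compound 1 to compound 3 (within the scatter). At this position, then, 4-chlorophenoxy and phenoxy cannot be told apart in this read-out, which the unrelated pair of compounds 1 and 2 could not show. Nothing at hand gives a reason for this result. From the compounds shown here alone, what remains open is how a trifluoromethyl group, an amine or a carboxylic acid on that same carbon would read. Also open, going by these compounds, is whether removing chloro would read the same way in a compound with a different side chain.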